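The source may report more compounds than this note shows. Statements on the series, on what has been measured and on what is new or still open speak of the compounds shown alone.

Measured compounds:
Compound 1, `C#CCN(Cc1ccc2nc(C)nc(O)c2c1)c1ccc(C(=O)N[C@@H](CC(C)C(=O)O)C(=O)N[C@@H](CCC(=O)O)C(=O)O)cc1` — 500 nM
Compound 2, `C#CCN(Cc1cc2c(O)nc(C)nc2cc1C)c1ccc(C(=O)N[C@@H](CCC(=O)O)C(=O)N(CC)[C@@H](CCC(=O)O)C(=O)O)c(F)c1` — 73 nM

The two measured compounds were tested in a functional assay on WIL2 cells (Homo sapiens) for inhibition; a higher number here means a weaker inhibitor, a lower number a stronger inhibitor. Compound 1 gives 500 nM, the higher of the two numbers, and compound 2 gives 73 nM, a number well apart from that of compound 1 and beyond the usual scatter. For the measured compounds named here, the two compounds differ in several places at once, so their values alone say only that compound 2 is the stronger inhibitor of the pair; no single structural cause can be drawn from them.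

The unmeasured compound 3, `C#CCN(Cc1ccc2nc(C)nc(O)c2c1)c1ccc(C(=O)N[C@@H](CC(C)(C)C(=O)O)C(=O)N[C@@H](CCC(=O)O)C(=O)O)cc1`, stands one change away from compound 1: methyl in place of hydrogen on a saturated chain carbon bound to a carbonyl carbon and two saturated chain carbons. Going by the values given here, nothing among the measured compounds shows what such a change does in this assay, so the expectation rests on the small size of the change. A step of no more than the scatter is expected, in either direction, and the step from compound 1 to compound 3, a 1.2-fold higher number from compound 1 to compound 3 (0.08 log units; within the scatter), is the estimate. For compound 3 a value of 600 nM is expected, with a range from 200 nM to 1800 nM.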

Compound 3, half-maximal inhibitory concentration: 370 nM
Compound 3: middle estimate off by 1.6-fold (0.21 log units), on the high side; low and high end bracket the measured number.
By their numbers in this assay, from the lowest: compound 2; then compounds 3 and 1 (each within the scatter of the next).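

In this assay, for the compounds shown here, the swap of 2-carboxypropyl for 2-carboxy-2-methylpropyl gives a 1.4-fold lower number from compound 1 to compound 3 (0.13 log units; within the scatter) and so provides the one step in this set that isolates a single place in the structure. At this saturated chain carbon bound to a carbonyl carbon and two saturated chain carbons, a methyl can therefore stand in place of hydrogen while the numbers of the two compounds remain indistinguishable, which the earlier pair, differing in several places at once, could not show. Nothing available gives a reason for this result.

What the compounds leave open is whether a group other than methyl on this same carbon, such as an ethyl, a longer chain, a hydroxyl or an amine, would also leave the number within the scatter or would move it clearly in either direction. As far as these compounds go, it also remains open whether methyl at this carbon would give a similar step on a core other than that of compound 1.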